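Swapping a fluorinated alcohol for an acetate ester

This account rests on a few compounds, and the source may have more. Where it says the series, first, only, none or still open, it means among the compounds named here.

Measured compounds:
compound 1 `CCC(O)Cc1cc(-c2ccnc3[nH]nc(C(F)(F)F)c23)cc(C2(C#N)CC2)c1`: 49 nM
compound 2 `N#CC1(c2cc(CC(O)C(F)(F)F)cc(-c3ccnc4[nH]nc(C(F)(F)F)c34)c2)CC1`: 267 nM

Within the data shown here, compound 2 gives the higher of the two numbers in an assay on isolated protein for inhibition of protein kinase C epsilon type (Homo sapiens), read by coupled enzyme assay; a lower number here means a stronger inhibitor, a higher number a weaker inhibitor; the only neighbour is compound 1, which gives 49 nM. Compound 3 `CC(=O)OCCc1cc(-c2ccnc3[nH]nc(C(F)(F)F)c23)cc(C2(C#N)CC2)c1` differs from compound 2 by acetoxymethyl in place of 2,2,2-trifluoro-1-hydroxyethyl on a saturated chain carbon bound to an aromatic carbon, the shared core staying untouched. Among the measured compounds shown here, the one measured step, a 5.4-fold higher number from compound 1 to compound 2 (0.74 log units; beyond the scatter), shows that putting a trifluoromethyl on the hydroxyl-bearing chain carbon raised the number. For the measured compounds named here, compound 3 removes that trifluoromethyl again, but it also gives up the hydroxyl and brings in an ester, a combination no measured pair covers. The expected step in this assay is therefore a modest drop in the number, roughly back toward compound 1, with broad uncertainty: a 2.4-fold lower number from compound 2 to compound 3 (0.39 log units; beyond the scatter). Compound 3 is thus estimated at 110 nM, within a range of 30 nM to 400 nM.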

Compound 3, inhibition constant: 119 nM
Beside the measured number, compound 3's estimate is 1.1-fold (0.03 log units) below it, and the stated range covers the measured number.
By their numbers in this assay, from the lowest: compound 1; then compound 3; then compound 2.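

In this assay, the place on a saturated chain carbon bound to an aromatic carbon does not need a hydroxyl for a number below that of compound 2: acetoxymethyl, with 0 hydrogen-bond donors, gives a 2.2-fold lower number from compound 2 to compound 3 (0.35 log units; beyond the scatter) in exchange for 2,2,2-trifluoro-1-hydroxyethyl. The ester does not match the plain alcohol, however, as acetoxymethyl in place of 1-hydroxypropyl gives a 2.4-fold higher number from compound 1 to compound 3 (0.39 log units; beyond the scatter) and leaves compound 1 with the lowest number of the three. Nothing measured here explains either shift.

As far as these compounds go, it remains open how other groups at this place, such as an amide, a carboxylic acid or a longer carbon chain, would compare with the ester and the two alcohols. A simple ether would help separate the role of the ester's carbonyl from that of its chain oxygen.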